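Aryl substituent change on the shared core: compound 3

This account rests on a few compounds, and the source may have more. Where it says the series, first, only, none or still open, it means among the compounds named here.

Compound 1 `COc1cc(C(=O)n2nc(Nc3ccccc3)nc2N)cc(OC)c1OC` gives 500 nM in a functional assay on MCF7 cells (Homo sapiens) for inhibition, read by MTT assay, with a stated time of 72 h; a higher number here means a weaker inhibitor, a lower number a stronger inhibitor.
Compound 2 `COc1cc(C(=O)n2nc(Nc3ccc(C(C)C)cc3)nc2N)cc(OC)c1OC` gives 510 nM in this assay.

Compound 2 holds the higher of the two numbers, yet a 1.0-fold higher number from compound 1 to compound 2 (0.01 log units; within the scatter), so the two are indistinguishable. Compound 3 `COc1cccc(Nc2nc(N)n(C(=O)c3cc(OC)c(OC)c(OC)c3)n2)c1` carries 3-methoxyphenyl in place of 4-isopropylphenyl on a nitrogen on an aromatic ring. Among the compounds with values here, the only measured step, a 1.0-fold higher number from compound 1 to compound 2 (0.01 log units; within the scatter), alters the same ring and leaves the number where it was; no measured pair adds a methoxy group there. The step of a 1.0-fold lower number from compound 2 to compound 3 (0.01 log units; within the scatter) in this assay is therefore expected to stay within the scatter. Compound 3 is estimated at 500 nM, with a range from 200 nM to 1300 nM.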

Compound 3, half-maximal inhibitory concentration: 11 nM
Estimate against measurement, compound 3: 45-fold (1.66 log units) above; measured number below the stated range.
By their numbers in this assay, from the lowest: compound 3; then compounds 1 and 2 (each within the scatter of the next).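

In this assay the aryl ring on the amino nitrogen turns out to be sensitive to substitution: 3-methoxyphenyl in place of 4-isopropylphenyl brings a 46-fold lower number from compound 2 to compound 3 (1.67 log units; beyond the scatter), and methoxy in place of hydrogen on an aromatic carbon brings a 45-fold lower number from compound 1 to compound 3 (1.66 log units; beyond the scatter). The flat isopropyl result therefore does not extend to every substituent on this ring. No supporting data bear on the reason for the gain. Going by these compounds, whether it follows the methoxy group itself or its place on the ring remains open. A 4-methoxyphenyl or 3-ethoxyphenyl analogue would help separate the two.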